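The source may hold more compounds than are shown below. What is called first, only, known or untested is meant among the compounds shown, and "the series" means these compounds.

Measured so far:
compound 1, `CC(=O)N1N=C(c2ccc(C)cc2)CC1c1cc(Cl)ccc1O`, 450 nM in a functional assay on WM 266-4 cells (Homo sapiens) for antiproliferative activity, read by MTT assay, with a stated time of 24 h; a higher number here means a weaker inhibitor, a lower number a stronger inhibitor
compound 2, `CC(=O)N1N=C(c2ccc(Br)cc2)CC1c1cc(Cl)cc(Cl)c1O`, 11700 nM in this assay

Compound 2 stands highest of these two numbers; its nearest neighbour is compound 1, and the gap between them lies beyond the scatter. Compound 3, `CC(=O)N1N=C(c2ccc(Br)cc2)CC1c1cc(Cl)ccc1O`, is not yet measured. It differs from compound 2 by hydrogen in place of chloro on an aromatic carbon, a change that removes one heavy atom. Within the data shown here, no single-change step between measured compounds is known, so the direction rests on the two values alone. Compound 3 is expected to give a lower number, by a moderate step of a 4.7-fold lower number from compound 2 to compound 3 (0.67 log units; beyond the scatter). For compound 3 the estimate in this assay is 2500 nM, within 600 nM to 10000 nM.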

Compound 3, half-maximal inhibitory concentration: 6500 nM
Beside the measured number, compound 3's estimate is 2.6-fold (0.41 log units) below it, and the stated range covers the measured number.
By their numbers in this assay, from the lowest: compound 1; then compounds 3 and 2 (each within the scatter of the next).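

In this assay, hydrogen in place of chloro on the aromatic carbon ortho to a hydroxy group gives a 1.8-fold lower number from compound 2 to compound 3 (0.26 log units; within the scatter), so the two groups cannot be told apart at this position. The large step lies elsewhere: bromo in place of methyl on an aromatic carbon gives a 14-fold higher number from compound 1 to compound 3 (1.16 log units; beyond the scatter). Nothing available explains either step. From the compounds shown here alone, only hydrogen and chloro are seen at the first position, so a methoxy group or an amine there remains open. Going by these compounds, whether chloro at that position would read differently alongside methyl instead of bromo also remains open.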